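Cytotoxicity Estimate for a Hydroxymethyl Extension

The source may hold more compounds than are shown below. What is called first, only, known or untested is meant among the compounds shown, and "the series" means these compounds.

Compound 1 `Cn1cnc(CS(=O)(=O)c2ccc(Br)cc2)c1[N+](=O)[O-]`: > 694000 nM in an ADME assay on THP-1 cells (Homo sapiens) for cytotoxicity, read by flow cytometry and propidium iodide staining, with a stated time of 72 h; on this read-out lower numbers stand for stronger inhibition and higher numbers for weaker inhibition
Compound 2 `Cc1nc(CS(=O)(=O)c2ccc(Br)cc2)c([N+](=O)[O-])n1C`: 326000 nM

Compound 1 returns only a limit in this assay, (the limit of > 694000 nM in this assay, at which 1 of the 2 values shown sits), not a number. Compound 2 is the only compound with a number shown, and it stands alone with 326000 nM. Within the data shown here, the single measured step, an at least 2.1-fold lower number from compound 1 to compound 2 (0.32 log units; beyond the scatter), concerns a methyl in place of hydrogen on an aromatic carbon.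

Compound 3 `Cc1nc(CS(=O)(=O)c2ccc(Br)cc2)c([N+](=O)[O-])n1CCO` differs from compound 2 by hydroxymethyl in place of hydrogen on a saturated chain carbon bound to an aromatic nitrogen. This change sits on a saturated chain carbon bound to an aromatic nitrogen, a different place and a different kind of group than the measured step covers, so that step does not bear on it directly. No step beyond the scatter is expected, a 1.0-fold higher number from compound 2 to compound 3 (0.01 log units; within the scatter). Compound 3 is therefore estimated at 330000 nM, with a range from 150000 nM to 700000 nM.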

Compound 3, half-maximal inhibitory concentration: 124000 nM
Compound 3: the middle estimate sits 2.7-fold (0.43 log units) above what was measured; the whole stated range lies above it.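

In this assay, the change from methyl to 2-hydroxyethyl gives a 2.6-fold lower number from compound 2 to compound 3 (0.42 log units; beyond the scatter). Among these compounds, the earlier compounds offered a single step, at an aromatic carbon, so this is the first indication that a change on a saturated chain carbon bound to an aromatic nitrogen also registers on this read-out, and that it does so in the direction of stronger inhibition. Nothing shown here accounts for the size or direction of this step.

Whether the lower number follows the oxygen of the hydroxymethyl group or simply the added chain remains open, since the compounds shown offer no ethyl group in this place to separate the two. Going by these compounds, how a longer chain ending in a hydroxyl, an amine or a carboxylic acid would read at this position also remains open.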